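The source may report more compounds than this note shows. Statements on the series, on what has been measured and on what is new or still open speak of the compounds shown alone.

Compound 1, `O=C(NCc1ccc(S(=O)(=O)c2cncc(C(F)(F)F)c2)cc1)N1Cc2ccncc2C1`: in a functional assay on A2780 cells (Homo sapiens) for cytotoxicity, read by sulforhodamine B assay, with a stated time of 72 h (a higher number here means a weaker inhibitor, a lower number a stronger inhibitor), compound 1 gives 10 nM.
Compound 2, `O=C(NCc1ccc(S(=O)(=O)C2CCC(F)(F)CC2)cc1)N1Cc2ccncc2C1`: in this assay compound 2 gives 13 nM.
Compound 3, `O=C(NCc1ccc(S(=O)(=O)C2CCCOC2)cc1)N1Cc2ccncc2C1`: in this assay compound 3 gives 32 nM.

Among these three, compound 1 has the lowest number, but its step to compound 2, a 1.3-fold higher number from compound 1 to compound 2 (0.11 log units; within the scatter), lies within the scatter, so the two cannot be ordered; only compound 3 stands beyond it, with a 3.2-fold higher number from compound 1 to compound 3 (0.51 log units; beyond the scatter). The unmeasured compound 4, `O=C(NCc1ccc(S(=O)(=O)C2CCN(C3COC3)CC2)cc1)N1Cc2ccncc2C1`, differs from compound 1 at one place: 1-(oxetan-3-yl)piperidin-4-yl in place of 5-(trifluoromethyl)pyridin-3-yl on a sulfonyl sulfur. The measured steps that bear on this all swap the same aromatic group on the sulfonyl sulfur for a saturated ring: a 1.3-fold higher number from compound 1 to compound 2 (0.11 log units; within the scatter), a 3.2-fold higher number from compound 1 to compound 3 (0.51 log units; beyond the scatter), and between the two saturated rings a 2.5-fold higher number from compound 2 to compound 3 (0.39 log units; beyond the scatter). Neither saturated ring gave a lower number than compound 1, and the oxan-3-yl ring gave the higher of the two. The group entering in compound 4 is likewise saturated, so a modest rise in the number is expected, in line with the oxan-3-yl case. Compound 4 is therefore estimated at 40 nM, with a range from 12 nM to 130 nM, meaning an expected step of a 4.0-fold higher number from compound 1 to compound 4 (0.60 log units; beyond the scatter).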

Compound 4, half-maximal inhibitory concentration: 7.4 nM
The estimate for compound 4 lay 5.4-fold (0.73 log units) above the measured number; measured number below the stated range.
By their numbers in this assay, from the lowest: compounds 4, 1 and 2 (each within the scatter of the next); then compound 3.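

On the sulfonyl sulfur, a saturated group containing two rings can stand in for the aromatic group: in this assay the swap to 1-(oxetan-3-yl)piperidin-4-yl gives a 1.4-fold lower number from compound 1 to compound 4 (0.13 log units; within the scatter) and, against the difluorinated ring, a 1.8-fold lower number from compound 2 to compound 4 (0.24 log units; within the scatter) and both steps lie within the scatter, so these three compounds cannot be ordered. Saturated groups at this place are not interchangeable, since the same group gives a 4.3-fold lower number from compound 3 to compound 4 (0.64 log units; beyond the scatter) and so the higher number of the oxan-3-yl ring does not carry over to every saturated group. Nothing available here accounts for this difference between the saturated groups.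

The compounds shown leave open how much of the result depends on the oxetan-3-yl group, as opposed to the piperidin-4-yl ring that carries it. A plain piperidin-4-yl ring, or one bearing a methyl or acetyl group in place of the oxetan-3-yl group, would address that.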